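Does a chloro group shift cell tolerance?

The compounds below may be only part of what the source reports. "The series", "measured", "known", "first", "only" and "open" are said of these compounds alone.

- compound 1 `COc1ccc(/C=C2\CCC/C(=C\c3ccc(OC)cc3)C2=O)cc1` gives 178000 nM
- compound 2 `COc1ccc(/C=C2\CCC/C(=C\c3ccccc3)C2=O)cc1` gives 291000 nM

Both numbers come from an ADME assay on Vero cells (Chlorocebus sabaeus) for inhibition; a higher number here means that more compound is tolerated, a lower number that less compound is tolerated. Within the data shown here, compound 2 stands level with the only other measured compound, as the one measured step shows: a 1.6-fold higher number from compound 1 to compound 2 (0.21 log units; within the scatter). That step put hydrogen in place of methoxy on an aromatic carbon. Compound 3 `COc1ccc(/C=C2\CCC/C(=C\c3ccccc3Cl)C2=O)cc1` carries a different change, (chloro in place of hydrogen on an aromatic carbon), with chloro in place of hydrogen, ortho to a large group. Among the measured compounds shown here, no measured step covers this swap, and the one available stayed small, so no shift beyond the scatter is expected in this assay. The expected change is a 1.3-fold lower number from compound 2 to compound 3 (0.10 log units; within the scatter). For compound 3 the estimate is 230000 nM, with an expected range of 100000 nM to 500000 nM.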

Compound 3, half-maximal cytotoxic concentration: 238000 nM
Beside the measured number, compound 3's estimate is 1.0-fold (0.01 log units) below it; low and high end bracket the measured number.
By their numbers in this assay, from the lowest: compounds 1, 3 and 2 (each within the scatter of the next).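

In this assay, chloro in place of hydrogen on an aromatic carbon, ortho to a large group, gives a 1.2-fold lower number from compound 2 to compound 3 (0.09 log units; within the scatter). Replacing 4-methoxyphenyl with 2-chlorophenyl gives a 1.3-fold higher number from compound 1 to compound 3 (0.13 log units; within the scatter), so this assay does not tell these two groups apart. No supporting data bear on this result. From the compounds shown here alone, whether this position would respond to a different kind of group, such as an amine or a carboxylic acid, stays open. So does whether chloro behaves the same way elsewhere on the ring.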